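The source may hold more compounds than are shown below. What is called first, only, known or untested is meant among the compounds shown, and "the series" means these compounds.

Measured compounds:
Compound 1, `CC1NC(C#N)(CO)C(O)C(O)C1O`: 110 nM
Compound 2, `CC1NC(CN)(CO)C(O)C(O)C1O`: 160 nM

In an assay on isolated protein for inhibition of tissue alpha-L-fucosidase (Homo sapiens) (a lower number here means a stronger inhibitor, a higher number a weaker inhibitor), compound 1 gives 110 nM and compound 2 gives 160 nM. Compound 2 stands beside compound 1 on these two numbers, separated from it only by a 1.5-fold higher number from compound 1 to compound 2 (0.16 log units; within the scatter), a gap that the scatter of repeated measurements covers. The shared core thus tolerates the exchange of the cyano group for aminomethyl without a change that can be read as real.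

Compound 3, `CC1NC(CO)(CNC(=O)CN)C(O)C(O)C1O`, carries the change ((aminomethyl)carbonyl in place of hydrogen on an amine nitrogen). For the measured compounds named here, no measured step touches an amine nitrogen in this way; the only step available, from cyano to aminomethyl, was within the scatter and speaks only for the carbon substituent, not for what is attached to its nitrogen. The expectation for compound 3 in this assay therefore rests on little: a step of a 2.5-fold higher number from compound 2 to compound 3 (0.40 log units; beyond the scatter) towards a higher number is expected, with wide uncertainty. Compound 3 is estimated at 400 nM in this assay, with a range from 100 nM to 1600 nM.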

Compound 3, half-maximal inhibitory concentration: 170 nM
Compound 3: middle estimate off by 2.4-fold (0.37 log units), on the high side; low and high end bracket the measured number.
By their numbers in this assay, from the lowest: compounds 1, 2 and 3 (each within the scatter of the next).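

In this assay, for the compounds shown here, placing (aminomethyl)carbonyl in place of hydrogen on the amine nitrogen gives a step that cannot be read as a real change (a 1.1-fold higher number from compound 2 to compound 3 (0.03 log units; within the scatter)), so this nitrogen, left bare in the earlier compounds, can carry an amide with its own terminal amine and the number holds. Going all the way from cyano to (((aminomethyl)carbonyl)amino)methyl on the saturated ring carbon likewise stays inside the scatter (a 1.5-fold higher number from compound 1 to compound 3 (0.19 log units; within the scatter)), which means that a nitrile, a short aminomethyl group and this much longer substituent all sit together at this place on the shared core. Nothing available here accounts for why the numbers stay together in this way.

The compounds shown leave open how far this tolerance runs, since all three lie so close that none marks an edge: an acetyl group without the terminal amine, or a longer chain ending in an amine or a carboxylic acid, could still shift the number. A benzoyl group on the same nitrogen would test whether a ring is accepted there as well.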